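Exchanging a Bromo-Hydroxyphenyl Group for an Amino-Hydroxyphenyl Group

The source may hold more compounds than are shown below. What is called first, only, known or untested is meant among the compounds shown, and "the series" means these compounds.

Measured compounds:
Compound 1, `C/C(=N\NC(=O)c1cccc(S(=O)(=O)N2CCOCC2)c1)c1ccc(F)cc1`; in a functional assay on EC9706 cells (Homo sapiens) for antiproliferative activity, read by MTT assay, with a stated time of 72 h (a lower number here means a stronger inhibitor, a higher number a weaker inhibitor), compound 1 gives > 100000 nM, which is a limit of the assay and not a number (the limit of > 100000 nM in this assay, at which 1 of the 3 values shown sits).
Compound 2, `C/C(=N\NC(=O)c1cccc(S(=O)(=O)N2CCOCC2)c1)c1ccc(O)cc1`; in this assay compound 2 gives 71400 nM.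
Compound 3, `C/C(=N\NC(=O)c1cccc(S(=O)(=O)N2CCOCC2)c1)c1cc(Br)ccc1O`; in this assay compound 3 gives 24700 nM.

Compound 3 holds the lowest of the two real numbers; its nearest neighbour is compound 2, separated by a 2.9-fold lower number from compound 2 to compound 3 (0.46 log units; beyond the scatter), while compound 1 offers only a limit. Compound 4, `C/C(=N\NC(=O)c1cccc(S(=O)(=O)N2CCOCC2)c1)c1cccc(N)c1O`, differs from compound 3 in one place: 3-amino-2-hydroxyphenyl in place of 5-bromo-2-hydroxyphenyl on a carbon with a double bond to nitrogen.

Two measured steps speak to this change. The swap of hydroxy for fluoro gave an at least 1.4-fold lower number from compound 1 to compound 2 (0.14 log units; that floor lies within the scatter), a small move, whereas moving to the 5-bromo-2-hydroxyphenyl group gave an at least 4.0-fold lower number from compound 1 to compound 3 (0.60 log units; beyond the scatter) and a 2.9-fold lower number from compound 2 to compound 3 (0.46 log units; beyond the scatter), both modest gains. Going by the values given here, compound 4 keeps a hydroxy but gives up the bromine, and no measured step tests an amino group. The expected outcome for compound 4 is therefore a slight drift to a higher number, a 1.6-fold higher number from compound 3 to compound 4 (0.21 log units; within the scatter), not clearly beyond the scatter. The estimate for compound 4 in this assay is 40000 nM, ranging from 12000 nM to 100000 nM.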

Compound 4, half-maximal inhibitory concentration: 3520 nM
For compound 4 the middle estimate is 11-fold (1.06 log units) above the measured one; measured number outside the range, below it.
By their numbers in this assay, from the lowest: compound 4; then compound 3; then compound 2. At a limit, above all of these: compound 1.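

In this assay, going by these compounds alone, the earlier compounds left the bromine of compound 3 looking like a useful part of the group on this carbon, yet replacing the 5-bromo-2-hydroxyphenyl group with 3-amino-2-hydroxyphenyl gives a 7.0-fold lower number from compound 3 to compound 4 (0.85 log units; beyond the scatter). The bromine is therefore not needed for a low number in this set, and the new group also gives a large step against the 4-hydroxyphenyl group, a 20-fold lower number from compound 2 to compound 4 (1.31 log units; beyond the scatter). Against the 4-fluorophenyl group the change gives an at least 28-fold lower number from compound 1 to compound 4 (1.45 log units; beyond the scatter), which is only a floor, with one end of the step a limit and not a number: the limit of > 100000 nM in this assay, at which 1 of the 4 values shown sits.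

This one change alters both the group and where it sits on the ring. The data do not separate the amino group alone from that shift. Going by these compounds, whether a methylamino or an acetamido group in its place would keep the low number also stays open.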